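The source may hold more compounds than are shown below. What is called first, only, known or untested is meant among the compounds shown, and "the series" means these compounds.

Series notes. Compound 1 `Cc1n[nH]c2ccc(-c3nc4cnc(N5CCN(C)CC5)cn4c3Nc3cccc(F)c3)cc12` carries a 3-fluorophenyl on the amine nitrogen and has no single number in a functional assay on MV4-11 cells (Homo sapiens) for inhibition, with a stated time of 120 h; on this read-out higher numbers stand for weaker inhibition and lower numbers for stronger inhibition: the entry for compound 1 reads "not determined" (no result reported). Compound 3 `Cc1n[nH]c2ccc(-c3nc4cnc(N5CCN(C)CC5)cn4c3Nc3ccccc3Cl)cc12` likewise has no result, its entry in this assay reading "not determined" (no result reported). Within the data shown here, the one number so far comes from compound 2 `Cc1n[nH]c2ccc(-c3nc4cnc(N5CCN(C)CC5)cn4c3Nc3ccc(F)cc3)cc12`, which in this assay gives 32300 nM; this is weak inhibition, and it is the only anchor for the series. Among the measured compounds shown here, no step between measured compounds can be formed, since only one of the three carries a value.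

Compound 4 `Cc1n[nH]c2ccc(-c3nc4cnc(N5CCN(C)CC5)cn4c3Nc3ccc(Cl)cc3)cc12` is the next entry for this assay. Against compound 1 the change is 4-chlorophenyl in place of 3-fluorophenyl on a nitrogen on an aromatic ring. For the measured compounds named here, with compound 1 itself lacking a number, no direction or size of the step from compound 1 to compound 4 can be read from the data; the expectation for compound 4 rests only on the weak value of compound 2 as the sole measured member. Compound 4 is therefore expected to stay in the same weak range, estimated at 25000 nM, with a range of 6000 nM to 100000 nM.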

Compound 4, half-maximal inhibitory concentration: 3510 nM
For compound 4 the middle estimate is 7.1-fold (0.85 log units) above the measured one; the whole stated range lies above it.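

In this assay, among these compounds, the halogen on the phenyl group carried by the amine nitrogen matters: chloro in place of fluoro on an aromatic carbon gives a 9.2-fold lower number from compound 2 to compound 4 (0.96 log units; beyond the scatter), the only readable step so far. The weak value of compound 2 is therefore not a fixed feature of the shared core, since a single atom change on this ring moves the number beyond the scatter. No measurement shown accounts for the size or direction of this step.

Steps to compound 1 and compound 3 cannot be read, so the effect of moving a halogen around this ring remains unresolved. Going by these compounds, whether bromo, methoxy or trifluoromethyl in place of the chloro of compound 4 would lower the number further also remains open.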